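Swapping one amine substituent on a fused triazine-type core

The source may report more compounds than this note shows. Statements on the series, on what has been measured and on what is new or still open speak of the compounds shown alone.

Compound 1 `CCC(COC)N(C)c1nc(C)nc2c1nnn2-c1ccc(C(C)C)cc1Br` sits in the middle of a small set of three compounds tested in an in vitro assay on 293-EBNA cells for binding affinity to corticotropin-releasing factor receptor 1 (Homo sapiens); on this read-out lower numbers stand for stronger inhibition and higher numbers for weaker inhibition. Compound 1 gives 11.2 nM, compound 2 `CCCCN(CC)c1nc(C)nc2c1nnn2-c1c(C)cc(C)cc1C` gives 27.5 nM, and compound 3 `CCC(CC)Nc1nc(C)nc2c1nnn2-c1c(C)cc(C)cc1C` gives 5.7 nM. The numbers for compound 1 and compound 3 lie within the scatter of each other, while compound 2 shows a higher number than either.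

Compound 4 `CCN(c1nc(C)nc2c1nnn2-c1ccc(C(C)C)cc1Br)C(COC)COC` differs from compound 1 only in the group attached to the amine on the shared core: a group of 10 heavy atoms (7 carbon, 1 nitrogen, 2 oxygen; no ring) in place of a group of 8 heavy atoms (6 carbon, 1 nitrogen, 1 oxygen; no ring), on an aromatic carbon. That amine sits next to the ring nitrogen and ortho to a fused ring, and it is meta to a methyl group.

Within the data shown here, only one measured step touches the same amine. From compound 2 to compound 3, a 4.8-fold lower number from compound 2 to compound 3 (0.68 log units; beyond the scatter), when (pentan-3-yl)amino replaced butyl(ethyl)amino. That step came with a different aryl ring and a different kind of amine, so it is a loose guide. The change to compound 4 keeps a dialkylated amine and adds one methoxy-bearing carbon, which is closer to a reshuffle than a rebuild, so compound 4 is expected to stay near compound 1 with a step of a 1.1-fold higher number from compound 1 to compound 4 (0.03 log units; within the scatter). The estimate for compound 4 is 12 nM, with a range from 4 nM to 36 nM.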

Compound 4, inhibition constant: 123 nM
Compound 4: middle estimate off by 10-fold (1.01 log units), on the low side; measured number outside the range, above it.
By their numbers in this assay, from the lowest: compounds 3 and 1 (each within the scatter of the next); then compound 2; then compound 4.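

In this assay, this amine turns out to be much less tolerant than its small change in size suggested: with the core and aryl ring kept the same, the group of 10 heavy atoms in place of the group of 8 heavy atoms gives an 11-fold higher number from compound 1 to compound 4 (1.04 log units; beyond the scatter) on this read-out. Neither group has a ring or a hydrogen-bond donor, so a large step here does not need a change of that kind. Nothing in the data explains the rise.

Compound 4 swaps the methyl on the amine nitrogen for ethyl and also adds a second methoxy-bearing arm, and these compounds cannot separate the two changes. Going by these compounds, how a hydroxyl in place of a methoxy, or a morpholine ring as the amine, would behave here also stays open.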